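The compounds below may be only part of what the source reports. "The series", "measured", "known", "first", "only" and "open" are said of these compounds alone.

Measured so far:
- compound 1, `C=CC(=O)Nc1ccc(Cn2nc(-c3ccc(Oc4ccccc4)cc3)cc2C(=O)O)cc1`, gives > 60000 nM
- compound 2, `CCOC(=O)c1cc(-c2ccc(Oc3ccccc3)cc2)nn1Cc1cccc(NC(=O)CCl)c1`, gives 500 nM
- compound 3, `C/C=C/C(=O)Nc1cccc(Cn2nc(-c3ccc(Oc4ccccc4)cc3)cc2C(=O)O)c1`, gives 31600 nM

All three were tested in a functional assay on Maver1 cells (Homo sapiens) for inhibition, read by luminescence and CellTiter-Glo, with a stated time of 72 h; on this read-out lower numbers stand for stronger inhibition and higher numbers for weaker inhibition. Compound 1 gives only a limit, (the limit of > 60000 nM in this assay, at which 1 of the 3 values shown sits), not a number. Of the two numbers that remain, compound 3 has the higher one, so it is the weaker of the two, and compound 2 sits at a lower number by a margin that is beyond the usual scatter.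

The step to follow leads from compound 3 to compound 4, `O=C(CCl)Nc1cccc(Cn2nc(-c3ccc(Oc4ccccc4)cc3)cc2C(=O)O)c1`, which has not yet been measured. The change is this: chloromethyl in place of prop-1-en-1-yl on a carbonyl carbon. The amide and the acid are kept; only the group on the carbonyl carbon changes.

For the measured compounds named here, no measured pair shows this change in isolation. Compound 2 also bears a chloromethyl group on its carbonyl carbon and gives 500 nM in this assay, but it differs from compound 4 in another place as well, so its value is only a hint. On that hint, compound 4 is expected to move to a lower number, and the step from compound 3 to compound 4 is estimated at a 5.3-fold lower number from compound 3 to compound 4 (0.72 log units; beyond the scatter). Compound 4 is therefore estimated at 6000 nM, within a range from 1000 nM to 30000 nM.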

Compound 4, half-maximal inhibitory concentration: 4700 nM
The estimate for compound 4 lay 1.3-fold (0.11 log units) above the measured number; the range from low to high includes it.
By their numbers in this assay, from the lowest: compound 2; then compound 4; then compound 3. At a limit, above all of these: compound 1.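

In this assay, changing only the group on the carbonyl carbon, with the amide and the acid kept, gives a 6.7-fold lower number from compound 3 to compound 4 (0.83 log units; beyond the scatter), so this position responds to the swap of prop-1-en-1-yl for chloromethyl. For the compounds shown here, compound 4 also forms the first one-place pair with compound 2: hydrogen in place of ethyl on an oxygen next to a carbonyl group gives a 9.4-fold higher number from compound 2 to compound 4 (0.97 log units; beyond the scatter), which shows that, with chloromethyl in place, the ethyl ester reads stronger than the acid. Compound 1 gives only a limit, not a number, so an at least 12-fold lower number from compound 1 to compound 4 (1.10 log units; beyond the scatter) is a bound rather than a measured size, and that step exchanges the whole 4-((vinylcarbonyl)amino)phenyl group for 3-(((chloromethyl)carbonyl)amino)phenyl: the limit of > 60000 nM in this assay, at which 1 of the 4 values shown sits.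

The compounds shown leave open how a bromomethyl group or a longer chain would read on the same carbonyl carbon, and how a primary amide would read in place of the acid or the ethyl ester. Also open, going by these compounds, is how the ethyl ester would read with prop-1-en-1-yl on the carbonyl carbon, and so whether the two changes simply add up.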